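The source may report more compounds than this note shows. Statements on the series, on what has been measured and on what is new or still open speak of the compounds shown alone.

Three compounds have been measured in a functional assay on MOLT-4 cells (Homo sapiens) for cytotoxicity, read by CCK-8 assay, with a stated time of 24 h; a lower number here means a stronger inhibitor, a higher number a weaker inhibitor:

- compound 1, `C=CC(=O)N1C(=O)CC(c2ccc([N+](=O)[O-])cc2)Sc2ccccc21`, gives 91500 nM
- compound 2, `C=CC(=O)N1C(=O)CC(c2ccc(OC)cc2)Sc2ccccc21`, gives 83200 nM
- compound 3, `C=CC(=O)N1C(=O)CC(c2ccccc2Cl)Sc2ccccc21`, gives 80300 nM

Of these three numbers compound 1 has the highest, yet both other compounds sit within the scatter of it, so the three cannot be told apart. The step from compound 1 to compound 2 was a 1.1-fold lower number from compound 1 to compound 2 (0.04 log units; within the scatter), and the step from compound 2 to compound 3 was a 1.0-fold lower number from compound 2 to compound 3 (0.02 log units; within the scatter). Both lie within the scatter.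

Compound 4, `C=CC(=O)N1C(=O)CC(c2ccc(C#N)cc2)Sc2ccccc21`, differs from compound 1 in one place: cyano in place of nitro on an aromatic carbon. Within the data shown here, only the step from compound 1 to compound 2 bears on this, since it also exchanges the nitro group on the aromatic carbon for another group, and that step stayed within the scatter. With cyano now entering in place of nitro, no step beyond the scatter is expected in this assay. The expected step is a 1.1-fold lower number from compound 1 to compound 4 (0.03 log units; within the scatter). Compound 4 is therefore estimated to give about 85000 nM in this assay, with a range from 40000 nM to 180000 nM.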

Compound 4, half-maximal inhibitory concentration: 88700 nM
Estimate against measurement, compound 4: 1.0-fold (0.02 log units) below, and the stated range covers the measured number.
By their numbers in this assay, from the lowest: compounds 3, 2, 4 and 1 (each within the scatter of the next).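

At this aromatic carbon, para to a large group, cyano is now a second replacement for nitro, and it gives a 1.0-fold lower number from compound 1 to compound 4 (0.01 log units; within the scatter) in this assay. Compound 4 also cannot be told apart from the compound carrying methoxy at this carbon (a 1.1-fold higher number from compound 2 to compound 4 (0.03 log units; within the scatter)) or from the compound with 2-chlorophenyl on the saturated ring carbon (a 1.1-fold higher number from compound 3 to compound 4 (0.04 log units; within the scatter)), so nitro, methoxy and cyano at this carbon have all given numbers within the scatter of one another. Nothing available explains why these numbers stay so close.

From the compounds shown here alone, it remains open whether an amine or a carboxylic acid at this aromatic carbon would produce a step beyond the scatter. Going by these compounds, it is equally open whether any change to the shared core would do so.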